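Inverting One Stereocentre on the Shared Core

This account rests on a few compounds, and the source may have more. Where it says the series, first, only, none or still open, it means among the compounds named here.

Measured compounds:
compound 1 `COc1cc(C(c2ccc(O)c(OC)c2)[C@@H](C)[C@H](C)CO)ccc1O` — reported only as a limit, > 100000 nM
compound 2 `COc1cc(C(c2ccc(O)c(OC)c2)[C@H](C)[C@@H](C)CF)ccc1O` — 34000 nM
compound 3 `COc1cc(C(c2ccc(O)c(OC)c2)[C@H](CO)C(C)C)ccc1O` — reported only as a limit, > 100000 nM

Of the compounds shown here, three built on the same core have been tested in a functional assay on HeLa cells (Homo sapiens) for cytotoxicity, read by WST assay, with a stated time of 48 h; on this read-out higher numbers stand for weaker inhibition and lower numbers for stronger inhibition. Going by the values given here, compound 2 is the only one with a numerical value in this assay. Compound 1 sits at the limit of the assay. Compound 3 sits at that same limit, so that the limit of > 100000 nM in this assay, at which 2 of the 3 values shown sit, holds for two of the three compounds. Among the steps, an at least 2.9-fold lower number from compound 1 to compound 2 (0.46 log units; beyond the scatter) and an at least 2.9-fold higher number from compound 2 to compound 3 (0.46 log units; beyond the scatter) are readable, while a step that the two limits leave unreadable from compound 1 to compound 3 is not. Compound 3 therefore stands at the weak end of what has been measured.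

Compound 4 `COc1cc(C(c2ccc(O)c(OC)c2)[C@@H](CO)C(C)C)ccc1O` differs from compound 3 in one respect: the two compounds have the same atoms and bonds and differ only in configuration as drawn: 1 of 1 stereo elements differ; a stereocentre at a saturated chain carbon is drawn R in compound 3 and S in compound 4. Among the compounds with values here, no measured step concerns a change of configuration alone; each of them replaces the branch on the saturated chain carbon. Nothing measured therefore points to a step beyond the scatter, and compound 4 is expected to stay near compound 3, giving a number no higher from compound 3 to compound 4 (the limit leaves the size open). The estimate for compound 4 in this assay is 100000 nM, with a range from 40000 nM to 300000 nM.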

Compound 4, half-maximal inhibitory concentration: > 100000 nM
Compound 4: only a limit was reported; the forecaster's own chance of this, stated with the estimate: 65%; the middle value lies on the limit itself.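

In this assay compound 4 gives > 100000 nM, which is a limit of the assay. The 1-(hydroxymethyl)-2-methylpropyl branch therefore stays at the weak end in both drawn configurations, R in compound 3 and S in compound 4, and the change from the 2-(fluoromethyl)-1-methylpropyl branch gives an at least 2.9-fold higher number from compound 2 to compound 4 (0.46 log units; beyond the scatter). The steps from compound 3 to compound 4 and from compound 1 to compound 4 cannot be read, so any effect of the inverted stereocentre stays hidden because both ends of each step are limits: the limit of > 100000 nM in this assay, at which 3 of the 4 values shown sit.

On these data alone, it remains open whether a 1-(fluoromethyl)-2-methylpropyl branch, in either configuration, would give a numerical value as compound 2 does. The compounds shown also leave open how an aminomethyl, a chloromethyl or a carboxylic acid in place of the hydroxymethyl would read in this assay.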